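Replacing benzyl with pyridin-3-yl on an amide nitrogen

A few compounds are considered here, and "the series" means these few. Any claim that something is new, unique, unknown or untested is made for them only; others in the source may bear on it.

Of the compounds shown here, three sharing one core have been tested in a functional assay on the whole organism for inhibition, with Rattus norvegicus as the target, read by paw edema, at a dose of 100 mg/kg by the oral route; on this read-out lower numbers stand for less inhibition and higher numbers for more inhibition at the one dose given (going by the name of the read-out). Compound 1 `CCOC(=O)c1c(O)c2cccnc2n(-c2ccccc2)c1=O` gives 23.5%. Compound 2 `O=C(NCc1ccccc1)c1c(O)c2cccnc2n(-c2ccccc2)c1=O` gives 1.6%, and compound 3 `O=C(Nc1cccc(Cl)c1)c1c(O)c2cccnc2n(-c2ccccc2)c1=O` gives 7.6%. Compound 2 sits at the low end of these numbers: the step of a number 21.9 percentage points lower from compound 1 to compound 2 (beyond the scatter) lies beyond the scatter, whereas the step of a number 6 percentage points higher from compound 2 to compound 3 (within the scatter) does not, so compound 2 and compound 3 cannot be told apart. Compound 4 `O=C(Nc1cccnc1)c1c(O)c2cccnc2n(-c2ccccc2)c1=O` has not yet been measured; it differs from compound 2 by pyridin-3-yl in place of benzyl on an amide-type nitrogen. Among the compounds with values here, the only measured step that bears on this is a number 6 percentage points higher from compound 2 to compound 3 (within the scatter), where one ring replaced benzyl on the same nitrogen without moving the number beyond the scatter. A similar outcome is expected here, namely a number 4.4 percentage points higher from compound 2 to compound 4 (within the scatter). Compound 4 is therefore estimated at 6%, between -5% and 20%.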

Compound 4, a percentage reported as inhibition, in the whole organism at one dose (the size of the read-out at that dose, not a potency): 30.3%
For compound 4 the middle estimate is 24.3 percentage points below the measured one; the measured number lies above the stated range.
By their numbers in this assay, from the lowest: compounds 2 and 3 (each within the scatter of the next); then compounds 1 and 4 (each within the scatter of the next).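

The ring on the amide-type nitrogen does matter: a number 28.7 percentage points higher from compound 2 to compound 4 (beyond the scatter) and a number 22.7 percentage points higher from compound 3 to compound 4 (beyond the scatter) both lie beyond the scatter, although benzyl and 3-chlorophenyl could not be told apart at this position. Replacing ethoxy on the carbonyl carbon therefore need not lower the number, since a number 6.8 percentage points higher from compound 1 to compound 4 (within the scatter) stays within the scatter, unlike the steps to the benzylamino and (3-chlorophenyl)amino compounds. Nothing available explains why pyridin-3-yl behaves differently here. Still open, as far as these compounds go, is whether pyridin-2-yl or pyridin-4-yl would match pyridin-3-yl. An unsubstituted phenyl on this nitrogen would also show how much depends on the ring nitrogen itself.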